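Fluorine for Hydroxyl on the Sulfonyl Aryl Ring

A few compounds are considered here, and "the series" means these few. Any claim that something is new, unique, unknown or untested is made for them only; others in the source may bear on it.

Compound 1, `O=S(=O)(Nc1ccc2oc(-c3ccccc3)nc2c1)c1ccc(Cl)c(Cl)c1`: 71000 nM
Compound 2, `O=S(=O)(Nc1ccc2oc(-c3ccccc3)nc2c1)c1ccccc1Cl`: 73000 nM
Compound 3, `O=S(=O)(Nc1ccc2oc(-c3ccccc3)nc2c1)c1ccc(O)cc1`: > 100000 nM

All three share one core and differ only in the aryl ring on the sulfonyl sulfur. They were tested in an ADME assay on HEK293 cells (Homo sapiens) for cytotoxicity, read by resazurin assay, with a stated time of 48 h; a higher number here means that more compound is tolerated, a lower number that less compound is tolerated. Compound 1 gives 71000 nM, and compound 2 gives 73000 nM; the step of a 1.0-fold higher number from compound 1 to compound 2 (0.01 log units; within the scatter) shows that the two chlorinated rings behave alike here. For compound 3 the assay reports only a limit, > 100000 nM, so its true number is not known. This is the limit of > 100000 nM in this assay, at which 1 of the 3 values shown sits. The steps of an at least 1.4-fold higher number from compound 1 to compound 3 (0.14 log units; that floor lies within the scatter) and an at least 1.3-fold higher number from compound 2 to compound 3 (0.13 log units; that floor lies within the scatter) are therefore only floors, and both lie within the scatter, so compound 3 cannot be set apart from the other two on the numbers shown.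

Compound 4, `O=S(=O)(Nc1ccc2oc(-c3ccccc3)nc2c1)c1cccc(F)c1`, is not yet measured. It differs from compound 3 by 3-fluorophenyl in place of 4-hydroxyphenyl on a sulfonyl sulfur. Among the compounds with values here, no measured step covers this exact exchange; the nearest guidance is that the chlorinated rings of compound 1 and compound 2 sit close to the limit reached by compound 3. A halogenated ring on the sulfonyl sulfur is thus expected to land near the values of compound 1 and compound 2, with no step beyond the scatter, and the estimated step is an at least 1.1-fold lower number from compound 3 to compound 4 (0.04 log units; that floor lies within the scatter). Compound 4 is expected to give 90000 nM, within an estimated range of 50000 nM to 160000 nM.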

Compound 4, half-maximal cytotoxic concentration: 68000 nM
The estimate for compound 4 lay 1.3-fold (0.12 log units) above the measured number, and the stated range covers the measured number.
By their numbers in this assay, from the lowest: compounds 4, 1 and 2 (each within the scatter of the next). At a limit, above all of these: compound 3.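

In this assay, 3-fluorophenyl in place of 2-chlorophenyl gives a 1.1-fold lower number from compound 2 to compound 4 (0.03 log units; within the scatter), and 3-fluorophenyl in place of 3,4-dichlorophenyl gives a 1.0-fold lower number from compound 1 to compound 4 (0.02 log units; within the scatter), so a fluorinated ring on the sulfonyl sulfur cannot be told apart from the chlorinated rings. Across compound 1, compound 2 and compound 4, neither the kind of halogen, nor the number of halogens, nor their placement on the ring produces a step that can be read beyond the scatter. The exchange of the hydroxyl-bearing ring for a fluorinated one, the first direct comparison of these two groups here, gives an at least 1.4-fold lower number from compound 3 to compound 4 (0.16 log units; that floor lies within the scatter), and this is only a floor, so the true size of the step stays unknown: the limit of > 100000 nM in this assay, at which 1 of the 4 values shown sits.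

As far as these compounds go, how far compound 3 really lies from the three halogenated compounds remains open, as does whether any ring on the sulfonyl sulfur can move this number beyond the scatter. Also open, from the compounds shown here alone, is what an amine or a carboxylic acid on that ring would do, and whether a methoxy group would behave like the hydroxyl of compound 3 or like the halogens.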